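The source may report more compounds than this note shows. Statements on the series, on what has been measured and on what is new or still open speak of the compounds shown alone.

Measured so far in an ADME assay on HepG2 2.2.15 cells (Homo sapiens) for cytotoxicity, read by MTT assay; a lower number here means that less compound is tolerated, a higher number that more compound is tolerated:
compound 1 `C=C1CC[C@@H]2[C@](C)(COC(=O)/C=C/c3ccccc3)[C@H](O)CC[C@@]2(C)[C@@H]1/C=C/C1=CCOC1=O` gives 183000 nM
compound 2 `C=C1CC[C@@H]2[C@](C)(COC(=O)c3cccnc3)[C@H](O)CC[C@@]2(C)[C@@H]1/C=C/C1=CCOC1=O` gives 113000 nM
compound 3 `C=C1CC[C@@H]2[C@](C)(COC(=O)c3cccs3)[C@H](O)CC[C@@]2(C)[C@@H]1/C=C/C1=CCOC1=O` gives 557000 nM

Compound 2 sits at the low end of this small set, together with compound 1, since the two cannot be told apart (a 1.6-fold lower number from compound 1 to compound 2 (0.21 log units; within the scatter)). Compound 3 stands clear of it (a 4.9-fold higher number from compound 2 to compound 3 (0.69 log units; beyond the scatter)).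

The next compound is compound 4 `C=C1CC[C@@H]2[C@](C)(COC(=O)c3cccnc3)[C@H](OC(=O)c3cccnc3)CC[C@@]2(C)[C@@H]1/C=C/C1=CCOC1=O`. Its difference from compound 2 is (pyridin-3-yl)carbonyl in place of hydrogen on an oxygen on a saturated carbon or, in words, (pyridin-3-yl)carbonyl in place of hydrogen on an oxygen on a saturated carbon. The free hydroxy thus becomes ((pyridin-3-yl)carbonyl)oxy.

The measured steps bear on this only indirectly. All of them exchange the group on a carbonyl carbon and leave the hydroxy untouched, including the remaining one (a 3.0-fold higher number from compound 1 to compound 3 (0.48 log units; beyond the scatter)). None shows what capping that hydroxy does. Going by the values given here, they suggest only that such changes have moved the number modestly, so a step of similar modest size is expected in this assay and its direction remains open. The middle of the estimate means an expected small change (a 1.4-fold higher number from compound 2 to compound 4 (0.15 log units; within the scatter)). Compound 4 is expected at 160000 nM in a range of 50000 nM to 500000 nM when tested.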

Compound 4, half-maximal cytotoxic concentration: > 1910000 nM
Compound 4: no number, only a limit (the forecaster's own chance of this, stated with the estimate: 10%); middle value at least 11-fold (1.07 log units) from the limit.
By their numbers in this assay, from the lowest: compounds 2 and 1 (each within the scatter of the next); then compound 3. At a limit, above all of these: compound 4.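

Going by these compounds alone, this is the first change at the hydroxy on the saturated carbon, since every earlier step exchanged only the group on a carbonyl carbon. Within the data shown here, replacing the hydroxy hydrogen with (pyridin-3-yl)carbonyl gives the largest step so far in this assay, with an at least 16-fold higher number from compound 2 to compound 4 (1.22 log units; beyond the scatter). A free hydroxy is therefore not required for a high number here, and this position moves the number further than any of the exchanges on the carbonyl carbon did. Compound 4 gives no exact number, only a limit, so the full size of this step remains unknown: the limit of > 1910000 nM in this assay, at which 1 of the 4 values shown sits.

With only this one cap on the hydroxy, the compounds shown cannot tell whether the rise comes from the (pyridin-3-yl)carbonyl group itself or from capping the oxygen with any group at all. Also open, as far as these compounds go, are how a small acetyl group, a methyl ether or an amine at this place would read, and whether the same cap would raise the number when the other ester carries thiophen-2-yl or 2-phenylethenyl, as in compound 3 and compound 1.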